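A few compounds are considered here, and "the series" means these few. Any claim that something is new, unique, unknown or untested is made for them only; others in the source may bear on it.

Measured in a functional assay on CHO cells for antagonist activity at prostaglandin E2 receptor EP3 subtype (Homo sapiens), read by FLIPR, with a stated time of 1 h; a higher number here means a weaker inhibitor, a lower number a stronger inhibitor:
compound 1 `CC1(c2ccc(-c3ccc4ccccc4c3)[nH]c2=O)OC(=O)NC1=O`: 20 nM
compound 2 `O=C1NC(=O)C(c2ccc(-c3ccc4ccccc4c3)[nH]c2=O)(C2CCCCC2)O1`: 7.94 nM
compound 3 `O=C1NC(=O)C(c2ccc(-c3ccc4ccccc4c3)[nH]c2=O)(C(F)(F)F)O1`: 126 nM

Compound 1 stands second highest of the three numbers in this assay; compound 2 sits lower, a 2.5-fold lower number from compound 1 to compound 2 (0.40 log units; beyond the scatter), and compound 3 sits higher, a 6.3-fold higher number from compound 1 to compound 3 (0.80 log units; beyond the scatter). Compound 4 `CC1(c2ccc(-c3ccc4ccccc4c3)[nH]c2=O)NC(=O)NC1=O` differs from compound 1 in one place: 4-methyl-2,5-dioxoimidazolidin-4-yl in place of 5-methyl-2,4-dioxo-1,3-oxazolidin-5-yl on an aromatic carbon. Within the data shown here, no measured step bears directly on this change. The steps on hand, a 2.5-fold lower number from compound 1 to compound 2 (0.40 log units; beyond the scatter), a 6.3-fold higher number from compound 1 to compound 3 (0.80 log units; beyond the scatter) and a 16-fold higher number from compound 2 to compound 3 (1.20 log units; beyond the scatter), all vary the group on the saturated ring carbon, which stays methyl in compound 4. With nothing that speaks to the ring exchange itself, the expected step is a 1.3-fold higher number from compound 1 to compound 4 (0.10 log units; within the scatter), not beyond the scatter. Compound 4 is estimated at 25 nM, with a range from 8 nM to 80 nM.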

Compound 4, inhibition constant: 316 nM
For compound 4 the middle estimate is 13-fold (1.10 log units) below the measured one; measured number outside the range, above it.
By their numbers in this assay, from the lowest: compound 2; then compound 1; then compound 3; then compound 4.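

The ring itself counts at this position, not only the group on its saturated carbon. With methyl held constant and ring size and net charge unchanged, 4-methyl-2,5-dioxoimidazolidin-4-yl in place of 5-methyl-2,4-dioxo-1,3-oxazolidin-5-yl gives a 16-fold higher number from compound 1 to compound 4 (1.20 log units; beyond the scatter), a change as large as a 16-fold higher number from compound 2 to compound 3 (1.20 log units; beyond the scatter). Nothing measured here explains this loss. Open, as far as these compounds go, is whether cyclohexyl or trifluoromethyl shifts the number in the same way on the entering ring, and how an amine or a carboxylic acid on the saturated ring carbon would read.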